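The compounds below may be only part of what the source reports. "The series", "measured", "known", "first", "only" and "open" are said of these compounds alone.

Measured so far in an ADME assay on MT4 cells (Homo sapiens) for cytotoxicity, read by spectrophotometry, with a stated time of 5 days; on this read-out lower numbers stand for higher toxicity in this test and higher numbers for lower toxicity in this test:

Compound 1 `CCn1cc(C(=O)O)c(=O)c2cc(F)c(N3CCN(CN4C(=O)/C(=N\NC(=S)NO)c5cc(C)ccc54)C(C)C3)c(F)c21` gives 244000 nM
Compound 2 `CCn1cc(C(=O)O)c(=O)c2cc(F)c(N3CCN(CN4C(=O)/C(=N\NC(=S)NO)c5cc(Cl)ccc54)C(C)C3)c(F)c21` gives 209000 nM
Compound 3 `CCn1cc(C(=O)O)c(=O)c2cc(F)c(N3CCN(CN4C(=O)/C(=N\NC(=S)NO)c5cc(F)ccc54)C(C)C3)c(F)c21` gives 187000 nM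

Compound 1 stands level with the other two, since a 1.2-fold lower number from compound 1 to compound 2 (0.07 log units; within the scatter) and a 1.3-fold lower number from compound 1 to compound 3 (0.12 log units; within the scatter) both stay inside the normal spread of repeat measurements. Compound 4 `CCn1cc(C(=O)O)c(=O)c2cc(F)c(N3CCN(CN4C(=O)/C(=N\NC(=S)NOC)c5cc(C)ccc54)C(C)C3)c(F)c21` is the unmeasured partner of compound 1. The two differ at one place methyl in place of hydrogen on an oxygen with methyl in place of hydrogen on an oxygen, so that hydroxyamino becomes methoxyamino.

Within the data shown here, no measured step touches that oxygen. All three swap one group on an aromatic carbon, and the remaining one, a 1.1-fold lower number from compound 2 to compound 3 (0.05 log units; within the scatter), is also inside the spread. These steps are therefore only indirect guides, and they give no reason to expect a step beyond the scatter in this assay or a firm direction. The expected result is a 1.1-fold lower number from compound 1 to compound 4 (0.04 log units; within the scatter) and this estimate is a small shift at most. For compound 4 the estimated value is 220000 nM with an expected range from 100000 nM to 450000 nM for a future measurement.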

Compound 4, half-maximal cytotoxic concentration: 156000 nM
Beside the measured number, compound 4's estimate is 1.4-fold (0.15 log units) above it; measured number inside the range.
By their numbers in this assay, from the lowest: compounds 4, 3, 2 and 1 (each within the scatter of the next).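

In this assay, among these compounds, the first change at this oxygen, where methyl takes the place of hydrogen and hydroxyamino becomes methoxyamino, reads as a 1.6-fold lower number from compound 1 to compound 4 (0.19 log units; within the scatter). The earlier steps shown here only swapped a group on an aromatic carbon, so this pair adds something new: on an oxygen whose other neighbour is an amide-type nitrogen, this one swap gives no step beyond the scatter in this test. No measurement shown here bears on what lies behind this result.

Still open, from the compounds shown here alone, is whether a longer chain such as ethyl on this oxygen, or an amino group in place of hydroxyamino, would also stay within the scatter of compound 1. Also open, going by these compounds, is whether the same methyl would read alike with the chloro of compound 2 or the fluoro of compound 3 on the aromatic carbon.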